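The source may report more compounds than this note shows. Statements on the series, on what has been measured and on what is new or still open speak of the compounds shown alone.

Measured so far:
Compound 1 `CCN(CC)S(=O)(=O)c1ccc(S(=O)(=O)N2CCC[C@@H](C(=O)N3CCC(C(F)(F)F)CC3)C2)cc1`: 320 nM
Compound 2 `CCN(CC)S(=O)(=O)c1ccc(S(=O)(=O)N2CCC[C@@H](C(=O)N3CCC(F)(F)CC3)C2)cc1`: 16 nM

In a functional assay on MIA PaCa-2 cells (Homo sapiens) for inhibition, read by MTT assay, with a stated time of 7 days (a higher number here means a weaker inhibitor, a lower number a stronger inhibitor), compound 2 gives 16 nM, the lowest of the two numbers shown. Its nearest neighbour is compound 1, which gives 320 nM; the step of a 20-fold lower number from compound 1 to compound 2 (1.30 log units; beyond the scatter) separates them. Compound 3 `CCN(CC)S(=O)(=O)c1ccc(S(=O)(=O)N2CCC[C@@H](C(=O)N3CCS(=O)(=O)CC3)C2)cc1` differs from compound 2 by 1,1-dioxothiomorpholin-4-yl in place of 4,4-difluoropiperidin-1-yl on a carbonyl carbon. No measured step makes this exchange; the one step shown alters the fluorine substitution of the same ring and does not settle direction or size here. Compound 3 is expected to give 60 nM, with a range from 15 nM to 250 nM. The expected step is a 3.8-fold higher number from compound 2 to compound 3 (0.57 log units; beyond the scatter), a modest rise.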

Compound 3, half-maximal inhibitory concentration: 900 nM
The estimate for compound 3 lay 15-fold (1.18 log units) below the measured number, and the stated range ends below it.
By their numbers in this assay, from the lowest: compound 2; then compound 1; then compound 3.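

On the carbonyl carbon in this assay, the change is not confined to the fluorinated piperidines: 1,1-dioxothiomorpholin-4-yl, with the same heavy-atom count as 4,4-difluoropiperidin-1-yl, gives a 56-fold higher number from compound 2 to compound 3 (1.75 log units; beyond the scatter). It also falls behind the weaker fluorinated compound, with a 2.8-fold higher number from compound 1 to compound 3 (0.45 log units; beyond the scatter), so compound 3 is the weakest of the three. No measurement shown accounts for this loss.

Going by these compounds, it remains open whether the ring sulfur or its two oxygens drive the rise. An unsubstituted piperidin-1-yl or a morpholin-4-yl ring on this carbonyl carbon could help separate them.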